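A few compounds are considered here, and "the series" means these few. Any claim that something is new, unique, unknown or untested is made for them only; others in the source may bear on it.

Working notes on the series, read in a functional assay on the whole organism for agonist activity, with Mus musculus as the target; a lower number here means that less compound is needed, a higher number that more compound is needed for the effect. Compound 1 `CCc1nccn1CC#CCN1CCCC1=O` gives > 100 mg/kg, which is a limit of the assay and not a number. Compound 2 `CC(C#CCN(C)C)N1CCCC1=O` gives 100 mg/kg. Compound 3 `CC(=O)N(C)CC#CCN1CCCC1` gives 0.3 mg/kg, the lower of the two actual numbers, and the gap separating it from compound 2 lies well beyond the scatter. Among the compounds with values here, these three compounds differ in more than one place, so no measured single-place step is available to calibrate the next change.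

Compound 4 `CCOC(=O)N(C)CC#CCN1CCCC1` remains to be measured in this assay. It carries ethoxy in place of methyl on a carbonyl carbon whose other neighbour is an amide-type nitrogen, which reads as acetyl to ethoxycarbonyl when cut one bond further out: ethoxy in place of methyl on a carbonyl carbon.

Within the data shown here, with no direct precedent for this change, the expectation rests on compound 3 at 0.3 mg/kg, since every other result so far lies upward from that value. A moderate upward step beyond the scatter is therefore expected, estimated as a 10-fold higher number from compound 3 to compound 4 (1.00 log units; beyond the scatter). The uncertainty is wide, and the estimate for compound 4 is 3 mg/kg, with an expected range of 0.6 mg/kg to 20 mg/kg.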

Compound 4, dose for half-maximal effect: 66 mg/kg
Beside the measured number, compound 4's estimate is 22-fold (1.34 log units) below it; the measured number lies above the stated range.
By their numbers in this assay, from the lowest: compound 3; then compounds 4 and 2 (each within the scatter of the next).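

In this assay, within the data shown here, this is the first step that changes one place only, and ethoxy in place of methyl on a carbonyl carbon whose other neighbour is the amide-type nitrogen reads as a 220-fold higher number from compound 3 to compound 4 (2.34 log units; beyond the scatter). This place is therefore sensitive: going from acetyl to ethoxycarbonyl is enough on its own to move the number far beyond the scatter, and the series now has one measured size for a change at this position. Compound 1 holds the only limit of the assay in the series, and little room remains for reading further upward steps from compound 4 as numbers: the limit of > 100 mg/kg in this assay, at which 1 of the 4 values shown sits.

Going by these compounds, whether the step follows the added length or the added oxygen of ethoxy stays open, and propionyl or methoxycarbonyl in place of acetyl would separate the two. Also open, on these data alone, is whether any replacement at this place, such as formyl or a dimethylaminocarbonyl group, keeps a number close to that of compound 3 at 0.3 mg/kg, or whether acetyl stands alone there.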